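The source may hold more compounds than are shown below. What is called first, only, known or untested is meant among the compounds shown, and "the series" means these compounds.

Measured so far:
compound 1 `O=C(CSc1nnc(-c2ccncc2)o1)N/N=C/c1ccc(O)cc1` — in a functional assay on BGC-823 cells (Homo sapiens) for cytotoxicity, read by MTT assay, with a stated time of 48 h (on this read-out lower numbers stand for stronger inhibition and higher numbers for weaker inhibition), compound 1 gives 7940 nM
compound 2 `O=C(CSc1nnc(-c2ccncc2)o1)N/N=C/c1ccccc1O` — in this assay compound 2 gives 6160 nM

Compound 2 stands at the lower of the two numbers, but the gap is only a 1.3-fold lower number from compound 1 to compound 2 (0.11 log units; within the scatter), so the two compounds are not separated. Compound 3 `COc1cc(/C=N/NC(=O)CSc2nnc(-c3ccncc3)o2)ccc1O` carries 4-hydroxy-3-methoxyphenyl in place of 2-hydroxyphenyl on a carbon with a double bond to nitrogen. Within the data shown here, the only step that bears on a change of the aryl group at this position is the one from compound 1 to compound 2, and it stayed within the scatter. No step beyond the scatter is therefore expected in this assay; the estimated step is a 1.0-fold lower number from compound 2 to compound 3 (0.01 log units; within the scatter). Compound 3 is expected to give 6000 nM, with a range of 2500 nM to 15000 nM.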

Compound 3, half-maximal inhibitory concentration: 4320 nM
Compound 3: middle estimate off by 1.4-fold (0.14 log units), on the high side; the range from low to high includes it.
By their numbers in this assay, from the lowest: compounds 3, 2 and 1 (each within the scatter of the next).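

In this assay, 4-hydroxy-3-methoxyphenyl in place of 2-hydroxyphenyl gives a 1.4-fold lower number from compound 2 to compound 3 (0.15 log units; within the scatter) and methoxy in place of hydrogen on an aromatic carbon gives a 1.8-fold lower number from compound 1 to compound 3 (0.26 log units; within the scatter) and so adds no separation. Compounds 1, 2 and 3 therefore remain unseparated, even with a second oxygen-bearing group on the aromatic ring at this position. From the compounds shown here alone, whether an amine, a carboxylic acid or a chlorine atom on this ring would move the number beyond the scatter stays open. No measured evidence bears on these results.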